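This account rests on a few compounds, and the source may have more. Where it says the series, first, only, none or still open, it means among the compounds named here.

Compound 1, `CCc1cc(C(C)=O)c(O)cc1OCCCCCCC#N`, has the higher number of the two compounds measured in an assay on isolated protein for inhibition of leukotriene B4 receptor 1 (Homo sapiens), tested at 10 uM; on this read-out lower numbers stand for less inhibition and higher numbers for more inhibition at the one concentration tested (going by the name of the read-out): compound 1 gives 103%, the highest of the two numbers. Among the measured compounds shown here, its nearest neighbour is compound 2, `COCc1cc(C(C)=O)c(O)cc1OCCCCCCC#N`, which in this assay gives 47%; the only measured step, a number 56 percentage points lower from compound 1 to compound 2 (beyond the scatter), changes a group on the core rather than the chain. Compound 3, `CCc1cc(C(C)=O)c(O)cc1OCCCCCCCC(C)(C)C#N`, differs from compound 1 at the far end of the chain: 2-cyano-2-methylpropyl in place of cyano on a saturated chain carbon, six bonds along the chain from an oxygen on an aromatic ring. For the measured compounds named here, no measured step touches that position, so the change from compound 1 to compound 2 does not speak directly to it; it only shows that this series can move a long way on a single change. With the number for compound 1 already high in this assay, the step expected for compound 3 is a number 18 percentage points lower from compound 1 to compound 3 (beyond the scatter), a modest lowering at most. Compound 3 is therefore estimated at 85%, in a range from 55% to 105%.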

Compound 3, a percentage reported as inhibition, at one concentration (the size of the read-out at that concentration, not a potency): 66%
For compound 3 the middle estimate is 19 percentage points above the measured one; the range from low to high includes it.
By their numbers in this assay, from the lowest: compound 2; then compound 3; then compound 1.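

In this assay, the far end of the chain proves to be a position where a single change moves the number: there is a number 37 percentage points lower from compound 1 to compound 3 (beyond the scatter) when 2-cyano-2-methylpropyl takes the place of cyano. Among the compounds shown here, the entering group keeps the nitrile and the same counts of hydrogen-bond donors and acceptors, so a large step can occur here without a change in those counts, and the core is not the only part of compound 1 that responds. No evidence on hand accounts for this step.

The compounds shown leave open whether an unbranched longer chain ending in a nitrile would keep the number of compound 1. They also leave open how a carboxylic acid or an amine would fare in place of the nitrile at this position.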